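A Benzyl for a Phenyl on Compound 3

The source may report more compounds than this note shows. Statements on the series, on what has been measured and on what is new or still open speak of the compounds shown alone.

Of the compounds shown here, three built on a shared core have been measured so far in an ADME assay on HeLa cells (Homo sapiens) for cytotoxicity, read by XTT assay; on this read-out lower numbers stand for higher toxicity in this test and higher numbers for lower toxicity in this test. In this test, compound 1 `C1=C(CCc2ccccc2)COc2ccccc21` gives 50000 nM, compound 2 `CC(Cc1ccccc1)C1=Cc2ccccc2OC1` gives 25000 nM and compound 3 `C1=C(CCCCc2ccccc2)COc2ccccc21` gives 100000 nM. Compound 3 lies within the usual scatter of compound 1. Only its gap to compound 2 goes beyond that scatter, with compound 3 carrying the higher number, which means lower toxicity in this test.

The next structure, compound 4 `C1=C(CCCCCc2ccccc2)COc2ccccc21`, differs from compound 3 in one place: benzyl in place of phenyl on a saturated chain carbon, four bonds along the chain from a double-bonded ring carbon. This puts benzyl in place of phenyl on a saturated chain carbon, four bonds along the chain from a double-bonded ring carbon.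

Among the measured compounds shown here, only one single-place step has been measured so far. It is a 2.0-fold lower number from compound 1 to compound 2 (0.30 log units; within the scatter), which puts methyl in place of hydrogen on a saturated chain carbon and stays within the scatter. That step is a different change, so it offers only a loose guide, and it points to no clear direction. No step beyond the scatter is therefore expected in this assay. The estimated change is no change at the digits printed from compound 3 to compound 4 (within the scatter). Compound 4 is expected at about 100000 nM, with an estimated range of 40000 nM to 250000 nM.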

Compound 4, half-maximal cytotoxic concentration: 100000 nM
The estimate for compound 4 equals the measured number at the digits printed; measured number inside the range.
By their numbers in this assay, from the lowest: compounds 2, 1, 3 and 4 (each within the scatter of the next, the first and the last beyond it).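

In this assay, among the compounds shown here, benzyl in place of phenyl on a saturated chain carbon, four bonds along the chain from a double-bonded ring carbon, gives no change at the digits printed from compound 3 to compound 4 (within the scatter) and so provides the first measured step at this place, since the only earlier step put methyl on a different chain carbon. Here, a single ring of carbon at the end of the chain can be swapped for a group one carbon larger, with the same ring and with neither group carrying a hydrogen-bond donor or acceptor, and the read-out stays within the usual scatter, which is a statement about this one pair and not a rule for the series. No measurement at hand explains why the number holds steady across this change.

The entering and leaving groups are both built of carbon alone. The step says nothing about how a group with other atoms would behave at this place. An amine or a carboxylic acid there, or a longer chain ending in the same phenyl ring, could move the number in either direction or leave it where it is.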